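Shortening the chain on the amino substituent of compound 3

The source may report more compounds than this note shows. Statements on the series, on what has been measured and on what is new or still open speak of the compounds shown alone.

Measured compounds and their values:
compound 1, `Nc1nc(O)nc2c1nc(O)n2Cc1ccccc1`, 0.1 uM
compound 2, `CCCCc1nc(N)c2nc(O)n(Cc3ccccc3)c2n1`, 0.03 uM
compound 3, `CCCCCNc1nc(N)c2nc(O)n(Cc3ccccc3)c2n1`, 0.1 uM

All three were tested in a functional assay (spleen, spleen) for activation, with Mus musculus as the target; a higher number here means that more compound is needed for the effect, a lower number that less compound is needed. Compound 3 stands level with compound 1, the two together giving the highest numbers of the three; compound 2 needs the least compound, as the step of a 3.3-fold higher number from compound 2 to compound 3 (0.52 log units; beyond the scatter) shows, while the step of no change at the digits printed from compound 1 to compound 3 (within the scatter) lies within the scatter. Compound 4, `CCCCNc1nc(N)c2nc(O)n(Cc3ccccc3)c2n1`, keeps the shared core of compound 3 and differs only in the amino substituent on the aromatic ring: hydrogen in place of methyl on a saturated chain carbon, four bonds along the chain from a nitrogen on an aromatic ring. Among the measured compounds shown here, no measured step removes a single carbon from such a chain, so the guidance is indirect. The step of a 3.3-fold lower number from compound 1 to compound 2 (0.52 log units; beyond the scatter) and the step of a 3.3-fold higher number from compound 2 to compound 3 (0.52 log units; beyond the scatter) show that larger changes at this aromatic carbon move the number only modestly, and the step of no change at the digits printed from compound 1 to compound 3 (within the scatter) shows no movement at all. A change of one chain carbon is therefore expected to leave the number within the scatter, so compound 4 is expected at 0.1 uM, between 0.03 uM and 0.3 uM, a step of no change at the digits printed from compound 3 to compound 4 (within the scatter) that is expected to be no larger than the scatter.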

Compound 4, minimum effective concentration: 1 uM
The estimate for compound 4 lay 10-fold (1.00 log units) below the measured number, outside the stated range (above it).
By their numbers in this assay, from the lowest: compound 2; then compounds 1 and 3 (each within the scatter of the next); then compound 4.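

In this assay, this end of the chain turns out to matter: hydrogen in place of methyl, which shortens pentylamino to butylamino, gives a 10-fold higher number from compound 3 to compound 4 (1.00 log units; beyond the scatter), a larger step than any seen among the first three compounds. Butylamino also stands apart from the other groups at the aromatic carbon, with a 10-fold higher number from compound 1 to compound 4 (1.00 log units; beyond the scatter) from hydroxy and a 33-fold higher number from compound 2 to compound 4 (1.52 log units; beyond the scatter) from butyl, and that second pair differs only by the amino nitrogen joining the chain to the core. No supporting measurement bears on what lies behind these steps.

As far as these compounds go, two amino chain lengths cannot define a trend, so it remains open whether a propylamino or a hexylamino group would extend this pattern or break it. Also open, from the compounds shown here alone, is whether a butoxy group at the same aromatic carbon would fall nearer compound 2 or compound 4.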